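Opening the Amide Ring of Compound 2 into a Chain

The compounds below may be only part of what the source reports. "The series", "measured", "known", "first", "only" and "open" are said of these compounds alone.

The measure throughout is a functional assay on the whole organism with Mus musculus as the target; a lower number here means that less compound is needed, a higher number that more compound is needed for the effect. Compound 1 `CN(C)C(=O)Cn1c(-c2ccccc2)nc2cccnc21` gives 35 mg/kg in this assay. Compound 2 `O=C(Cn1c(-c2ccc(Cl)cc2)nc2cccnc21)N1CCCC1` gives 17.9 mg/kg in this assay. Among the compounds with values here, only these two numbers are known, and the number of compound 2 and that of compound 1 lie within the usual scatter of each other, so on the present data the two compounds cannot be told apart, and no step between them can be claimed.

Compound 3 `CN(C)CCCNC(=O)Cn1c(-c2ccc(Cl)cc2)nc2cccnc21` differs from compound 2 in one place: (3-(dimethylamino)propyl)amino in place of pyrrolidin-1-yl on a carbonyl carbon. The amide carbonyl, its neighbouring saturated chain carbon and the whole shared core are untouched; only the group on the amide nitrogen side changes from a small ring to an open chain ending in a dimethylamino group.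

Within the data shown here, no measured pair shows what a change of this kind does here, so the expectation has to be cautious. The step of a 1.1-fold higher number from compound 2 to compound 3 (0.05 log units; within the scatter) is estimated to stay within the scatter, with no clear direction. Compound 3 is therefore expected to give about 20 mg/kg in this assay, with a likely range from 8 mg/kg to 50 mg/kg.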

Compound 3, dose for half-maximal effect: 64 mg/kg
For compound 3 the middle estimate is 3.2-fold (0.51 log units) below the measured one; measured number outside the range, above it.
By their numbers in this assay, from the lowest: compounds 2, 1 and 3 (each within the scatter of the next, the first and the last beyond it).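

In this assay, putting (3-(dimethylamino)propyl)amino in place of pyrrolidin-1-yl on a carbonyl carbon gives a 3.6-fold higher number from compound 2 to compound 3 (0.55 log units; beyond the scatter), so more compound is needed for the effect after this change. Within the data shown here, this is the first step that can be read at this position, since compound 1 and compound 2 differ in more than one place and lie within the scatter of each other; it shows that the group on the amide nitrogen side matters here, although the step is modest, and that this open chain compares unfavourably with the pyrrolidin-1-yl ring. No measurement at hand explains why the number rises.

The change alters several things at once, replacing the ring with an open chain, adding the amide hydrogen and adding a terminal dimethylamino group, so this single step cannot show which of them accounts for the rise. A plain butylamino chain with no terminal amine would help separate these features, while a piperidin-1-yl ring would show how much room the position offers for a ring larger than pyrrolidin-1-yl.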